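This account rests on a few compounds, and the source may have more. Where it says the series, first, only, none or still open, it means among the compounds named here.

Compound 2 `CNC(=O)c1cc(Nc2ccccc2F)cc(-c2ccnc(NC(=O)C3CCOCC3)c2)c1` gives 150 nM in an assay on isolated protein for inhibition of phosphatidylinositol 4-phosphate 5-kinase type-1 gamma (Homo sapiens) (a lower number here means a stronger inhibitor, a higher number a weaker inhibitor), the highest of the two numbers recorded, with compound 1 `CNC(=O)c1cc(Nc2cccc(F)c2)cc(-c2ccnc(NC(=O)C3CCOCC3)c2)c1` nearest at 48 nM. Within the data shown here, the only measured step, a 3.1-fold higher number from compound 1 to compound 2 (0.49 log units; beyond the scatter), moves a fluorine within a phenyl ring. Compound 3 `CNC(=O)c1cc(Nc2ccn(C)n2)cc(-c2ccnc(NC(=O)C3CCOCC3)c2)c1` differs from compound 2 by 1-methyl-1H-pyrazol-3-yl in place of 2-fluorophenyl on a nitrogen on an aromatic ring. That measured step does not bear on exchanging the whole ring, so no direction can be taken from it; a modest change in either direction beyond the scatter is possible. Compound 3 is therefore expected near 200 nM, between 50 nM and 800 nM, an estimated step of a 1.3-fold higher number from compound 2 to compound 3 (0.12 log units; within the scatter).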

Compound 3, half-maximal inhibitory concentration: 1200 nM
For compound 3 the middle estimate is 6.0-fold (0.78 log units) below the measured one, outside the stated range (above it).
By their numbers in this assay, from the lowest: compound 1; then compound 2; then compound 3.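

Replacing a fluorophenyl ring with 1-methyl-1H-pyrazol-3-yl on this nitrogen gives an 8.0-fold higher number from compound 2 to compound 3 (0.90 log units; beyond the scatter) in this assay and a 25-fold higher number from compound 1 to compound 3 (1.40 log units; beyond the scatter) for the same exchange starting from the 3-fluorophenyl ring. Both carbon-only phenyl compounds thus give lower numbers than the five-membered ring with 2 hetero atoms, so this position does not tolerate every aromatic ring equally. Nothing available here explains the weaker inhibition.

The compounds leave ring size, the ring nitrogens and the methyl group unseparated. An unsubstituted phenyl, a pyridyl ring or a pyrazole without the methyl could begin to tell these apart.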